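This account rests on a few compounds, and the source may have more. Where it says the series, first, only, none or still open, it means among the compounds named here.

Measured so far in a functional assay on DU-145 cells (Homo sapiens) for inhibition; a lower number here means a stronger inhibitor of growth, a higher number a weaker inhibitor of growth:

- compound 1 `O=S(=O)(/C=C/c1ccc(O)cc1)Cc1ccc(Nc2ncnc3ccccc23)cc1`: 19000 nM
- compound 2 `O=S(=O)(/C=C/c1ccc(Br)cc1)Cc1ccc(Nc2ncnc3ccc(Br)cc23)cc1`: 3000 nM
- compound 3 `O=S(=O)(/C=C/c1ccc(Cl)cc1)Cc1ccc(Nc2ncnc3ccc(Br)cc23)cc1`: 1000 nM

Compound 3 has the lowest of these three numbers. Compound 2 lies nearest to it and compound 1 furthest away, both beyond the usual scatter. The next compound to be measured is compound 4 `O=S(=O)(/C=C/c1ccc(O)cc1)Cc1ccc(Nc2ncnc3ccc(Br)cc23)cc1`, which has hydroxy in place of chloro on an aromatic carbon, para to a large group (hydroxy in place of chloro on an aromatic carbon).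

For the measured compounds named here, only one measured step involves this same place: a 3.0-fold lower number from compound 2 to compound 3 (0.48 log units; beyond the scatter). It is a modest step, and it exchanges one halogen for another, so it shows that the number can respond to a change here but says little about hydroxy itself.

A second clue comes from the 4-hydroxyphenyl group that compound 4 shares with compound 1. Compound 1 gives 19000 nM, while compound 3 gives 1000 nM. However, compound 1 also lacks the bromo on the shared core, so this gap combines two differences and cannot be credited to hydroxy alone.

A weaker inhibitor of growth therefore seems likely, with an expected move of a 5.0-fold higher number from compound 3 to compound 4 (0.70 log units; beyond the scatter). For compound 4 the estimated value is 5000 nM, with an expected range from 1500 nM to 15000 nM.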

Compound 4, concentration for 50% growth inhibition: 3000 nM
Compound 4: middle estimate off by 1.7-fold (0.22 log units), on the high side, and the stated range covers the measured number.
By their numbers in this assay, from the lowest: compound 3; then compounds 2 and 4 (each within the scatter of the next); then compound 1.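

In this assay, hydroxy in place of chloro on the aromatic carbon gives a 3.0-fold higher number from compound 3 to compound 4 (0.48 log units; beyond the scatter), so this position responds to a non-halogen group as well as to an exchange of one halogen for another. Hydroxy and bromo cannot be told apart here, with no change at the digits printed from compound 2 to compound 4 (within the scatter), which leaves chloro as the only one of the three groups at this position set apart from the others by more than the scatter. Compound 4 also provides a clean comparison for the shared core: with 4-hydroxyphenyl held constant, bromo in place of hydrogen gives a 6.3-fold lower number from compound 1 to compound 4 (0.80 log units; beyond the scatter), so this second position affects the number independently of any change on the phenyl ring. No measured evidence here accounts for these differences.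

Still open, on these data alone, is how an amine or a methoxy group at the same position would compare with chloro and hydroxy. Also open, as far as these compounds go, is whether the bromo on the core produces a similar step when chloro, rather than hydroxy, sits on the phenyl ring.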